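Trading a substituted pyridine for ethoxy

The source may report more compounds than this note shows. Statements on the series, on what has been measured and on what is new or still open speak of the compounds shown alone.

In a functional assay on a cell-free system (plasma, Homo sapiens) for inhibition, with Plasma (Rattus norvegicus) as the target (on this read-out higher numbers stand for weaker inhibition and lower numbers for stronger inhibition), compound 2 (`COc1c(C)cnc(COc2ccc3c(N4CCNCC4)cc(=O)oc3c2C)c1C`) gives 5800 nM, the higher of the two measured numbers, while compound 1 (`Cc1c(OCc2cccnc2)ccc2c(N3CCNCC3)cc(=O)oc12`) gives 1420 nM. Compound 3 (`CCOCOc1ccc2c(N3CCNCC3)cc(=O)oc2c1C`), not yet measured, carries ethoxy in place of 4-methoxy-3,5-dimethylpyridin-2-yl on a saturated chain carbon bound to an oxygen on an aromatic ring. Within the data shown here, one measured step bears on this change, a 4.1-fold higher number from compound 1 to compound 2 (0.61 log units; beyond the scatter), and it came with 4-methoxy-3,5-dimethylpyridin-2-yl replacing pyridin-3-yl. Among the measured compounds shown here, no ethoxy compound has been measured, so the evidence is indirect. A modest move to a lower number is expected, with an estimated 2.3-fold lower number from compound 2 to compound 3 (0.37 log units; beyond the scatter). Compound 3 is estimated at 2500 nM, with an expected range of 800 nM to 7500 nM.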

Compound 3, half-maximal inhibitory concentration: 1900 nM
The estimate for compound 3 lay 1.3-fold (0.12 log units) above the measured number, and the stated range covers the measured number.
By their numbers in this assay, from the lowest: compounds 1 and 3 (each within the scatter of the next); then compound 2.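

In this assay the change to ethoxy gives a 3.1-fold lower number from compound 2 to compound 3 (0.48 log units; beyond the scatter) and shows that, on this saturated chain carbon bound to an oxygen on an aromatic ring, a group with no ring can replace 4-methoxy-3,5-dimethylpyridin-2-yl without raising the number. A result of a 1.3-fold higher number from compound 1 to compound 3 (0.13 log units; within the scatter) leaves ethoxy and pyridin-3-yl indistinguishable at this place. No available evidence accounts for either step. As far as these compounds go, whether a longer chain such as butoxy or an amine such as dimethylamino would keep the number in this range remains open.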